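Adding one chloro to compound 2

The source may report more compounds than this note shows. Statements on the series, on what has been measured and on what is new or still open speak of the compounds shown alone.

In a functional assay on K562 cells (Homo sapiens) for inhibition, read by trypan blue exclusion, with a stated time of 48 h (a higher number here means a weaker inhibitor, a lower number a stronger inhibitor), compound 1 `Cc1ccc(NC(=O)/C=C/c2ccccc2)c(C(N)=O)c1` gives 5500 nM and compound 2 `NC(=O)c1cc(Br)ccc1NC(=O)/C=C/c1ccccc1` gives 5000 nM. Replacing the methyl of the first with the bromo of the second amounts to a 1.1-fold lower number from compound 1 to compound 2 (0.04 log units; within the scatter), so the two cannot be told apart. Compound 3 `NC(=O)c1cc(Cl)ccc1NC(=O)/C=C/c1cccc(Br)c1` yields no number, only a limit: > 10000 nM. For the measured compounds named here, compound 2 therefore stands level with compound 1, the only other compound with a true number.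

Compound 4 `NC(=O)c1cc(Br)ccc1NC(=O)/C=C/c1ccc(Cl)cc1` departs from compound 2 in a single place: chloro in place of hydrogen on an aromatic carbon. Its phenyl becomes 4-chlorophenyl. Going by the values given here, no measured step tests this place directly. Among the compounds with values here, the one clean step, a 1.1-fold lower number from compound 1 to compound 2 (0.04 log units; within the scatter), concerns a different place in the molecule, so it offers only weak guidance. It does show that one swap of a single group left the number within the scatter. Within the data shown here, compound 3 differs from compound 2 in more than one place, so it gives no clean step. The limit of compound 3, > 10000 nM, leaves open a weaker result.

The expectation therefore stays anchored on compound 2 at 5000 nM, leaning slightly towards a higher number. The estimated change is a 1.2-fold higher number from compound 2 to compound 4 (0.08 log units; within the scatter). Compound 4 is expected at about 6000 nM, with an estimated range from 2000 nM to 15000 nM.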

Compound 4, half-maximal inhibitory concentration: > 10000 nM
Compound 4: no number, only a limit; the forecaster's own chance of this, stated with the estimate: 30%; at least 1.6-fold (0.22 log units) between middle value and limit.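

For the compounds shown here, compound 4 is the first clean test of the phenyl end of the molecule, since the only earlier clean step, methyl to bromo, concerned a different place. Going from phenyl to 4-chlorophenyl, with the chloro para to a large group, gives an at least 2.0-fold higher number from compound 2 to compound 4 (0.30 log units; that floor lies within the scatter) in this assay, and that figure is only a floor, so the true step could be that small or considerably larger. As far as these compounds go, compound 4 gives a limit rather than a number, so this single added chloro cannot be said to have weakened the compound by any definite amount, and the size of the change remains unknown beyond that floor: the limit of > 10000 nM in this assay, at which 2 of the 4 values shown sit.

The compounds shown leave open whether a different group at this same place, such as fluoro, methoxy or an amine, would give a true number rather than a limit. They also leave open whether a chloro at another place on this phenyl would read any differently, and whether the result would hold with the methyl of compound 1 in place of the bromo.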